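The source may report more compounds than this note shows. Statements on the series, on what has been measured and on what is new or still open speak of the compounds shown alone.

Compound 1 `C[C@@H](NCC1CCN(CCCc2c[nH]c3ccc(-n4cnnc4)cc23)CC1)c1ccccc1` gives 14 nM in an assay on CHO cells for displacement of a labelled ligand from 5-hydroxytryptamine receptor 1B (Homo sapiens); a lower number here means a stronger inhibitor, a higher number a weaker inhibitor. Compound 2 `c1ccc2c(c1)CCC2NCC1CCN(CCCc2c[nH]c3ccc(-n4cnnc4)cc23)CC1`, in this assay, gives 25 nM; the step of a 1.8-fold higher number from compound 1 to compound 2 (0.25 log units; within the scatter) puts its number within the scatter of compound 1, so the two cannot be told apart. Compound 3 `CC(=O)Nc1ccc(CNCC2CCN(CCCc3c[nH]c4ccc(-n5cnnc5)cc34)CC2)cc1` carries the change (4-acetamidobenzyl in place of 2,3-dihydro-1H-inden-1-yl on an amine nitrogen). Going by the values given here, only the step from compound 1 to compound 2 bears on it, a swap on the same amine nitrogen that stayed within the scatter, so the expected step of a 1.4-fold higher number from compound 2 to compound 3 (0.15 log units; within the scatter) is small. Compound 3 is therefore estimated at 35 nM, between 10 nM and 120 nM.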

Compound 3, half-maximal inhibitory concentration: 8.9 nM
Beside the measured number, compound 3's estimate is 3.9-fold (0.59 log units) above it; the measured number lies below the stated range.
By their numbers in this assay, from the lowest: compounds 3, 1 and 2 (each within the scatter of the next, the first and the last beyond it).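

In this assay, going by these compounds alone, this amine nitrogen accepts a group with a hydrogen-bond donor and acceptor, which the 2,3-dihydro-1H-inden-1-yl group lacks, and the change gives a 2.8-fold lower number from compound 2 to compound 3 (0.45 log units; beyond the scatter), the first step here beyond the scatter. Set against 1-phenylethyl on the same nitrogen, 4-acetamidobenzyl gives a 1.6-fold lower number from compound 1 to compound 3 (0.20 log units; within the scatter), so those two groups cannot be told apart. Nothing available explains the shift. Still open, as far as these compounds go, is whether the acetamido group matters at all, or whether plain benzyl would do as well. A benzyl carrying an amine or a carboxylic acid in its place would test how much that part can vary.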